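The source may hold more compounds than are shown below. What is called first, only, known or untested is meant among the compounds shown, and "the series" means these compounds.

Measured in a functional assay on MDA-MB-231 cells (Homo sapiens) for antiproliferative activity, read by CCK-8 assay, with a stated time of 48 h; on this read-out lower numbers stand for stronger inhibition and higher numbers for weaker inhibition:
- Compound 1 `C/C=C/C(=O)N1CC(Oc2ccc(Oc3c(-c4ccc(F)cc4)sc4cc(O)ccc34)cc2)C1`: > 50000 nM, a limit
- Compound 2 `CN(C)C(=O)/C=C/CNCCOc1ccc(Oc2c(-c3ccc(F)cc3)sc3cc(O)ccc23)cc1`: > 50000 nM, a limit

Compound 1 offers no number, only the limit > 50000 nM. Compound 2 likewise reports only a limit, > 50000 nM. The whole measured picture is therefore (the limit of > 50000 nM in this assay, at which 2 of the 2 values shown sit).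

Compound 3 `O=C(/C=C/CN1CC(Oc2ccc(Oc3c(-c4ccc(F)cc4)sc4cc(O)ccc34)cc2)C1)N1CCC1` carries 3-((azetidin-1-yl)carbonyl)prop-2-en-1-yl in place of (prop-1-en-1-yl)carbonyl on an amine nitrogen in a ring.

Within the data shown here, one measured step bears on this change, a step that the two limits leave unreadable from compound 1 to compound 2. It replaces the same (prop-1-en-1-yl)carbonyl unit, together with the azetidine, by 2-((3-(dimethylcarbamoyl)prop-2-en-1-yl)amino)ethyl, and it gives no size to carry over. What it does show is that a chain of this kind left compound 2 at the limit too. No step beyond the scatter is therefore expected in this assay, in either direction, and compound 3 will most likely report a limit as well.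

The expected change is a number no higher from compound 1 to compound 3 (the limit leaves the size open).

For compound 3 the estimated value is 50000 nM, with an expected range of 20000 nM to 100000 nM.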

Compound 3, half-maximal inhibitory concentration: > 50000 nM
Compound 3 ended at the assay's limit (the forecaster's own chance of this, stated with the estimate: 75%); the middle value lies on the limit itself.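

In this assay compound 3 gives > 50000 nM, which is a limit. Among these compounds, compound 1 also reports only a limit, so no step between these two compounds can be read. The compounds shown leave open whether 3-((azetidin-1-yl)carbonyl)prop-2-en-1-yl changes the read-out at all, and their values offer no number to compare: the limit of > 50000 nM in this assay, at which 3 of the 3 values shown sit.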